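Methoxy for Fluoro on the Pendant Aryl Ring

This account rests on a few compounds, and the source may have more. Where it says the series, first, only, none or still open, it means among the compounds named here.

Of the compounds shown here, three have been measured. Compound 1 `Cn1cncc1[C@@](N)(c1ccc(C#N)cc1)c1cc2cc(C#N)cc(-c3cccc(F)c3)c2o1` and compound 3 `COc1cccc(-c2cc(C#N)cc3cc([C@](N)(c4ccc(C#N)cc4)c4cncn4C)oc23)c1` share one core, while compound 2 `Cn1cncc1C(O)(c1ccc(C#N)cc1)c1cc2cc([N+](=O)[O-])cc(-c3ccc(F)cc3)c2o1` carries a different one. In a functional assay on QG-56 cells (Homo sapiens) for antiproliferative activity (a lower number here means a stronger inhibitor, a higher number a weaker inhibitor), compound 1 gives 2 nM and compound 3 gives 1.5 nM. In this assay compound 2 gives 158 nM. The difference between the core of compound 2 and the core of compound 1 is not broken down here; the two values show compound 2 standing far apart from compound 1 and from compound 3, well beyond the scatter in both cases.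

Within the first core, the change methoxy in place of fluoro on an aromatic carbon produced a 1.3-fold lower number from compound 1 to compound 3 (0.12 log units; within the scatter). Compound 4 `COc1ccc(-c2cc([N+](=O)[O-])cc3cc(C(O)(c4ccc(C#N)cc4)c4cncn4C)oc23)cc1` is compound 2 with the same kind of change, (methoxy in place of fluoro on an aromatic carbon). The place is not identical: in compound 3 the methoxy sits meta to a large group, whereas in compound 4 it sits para to a large group, so the two changes are of the same kind rather than the same.

For compound 4 the step of a 1.2-fold lower number from compound 2 to compound 4 (0.08 log units; within the scatter) is expected to be small, because the same kind of change gave a 1.3-fold lower number from compound 1 to compound 3 (0.12 log units; within the scatter), which stayed within the scatter. The different place and the different core leave room for some deviation, so the range is kept wide. Compound 4 is estimated at 130 nM in this assay, with the expected range running from 55 nM to 320 nM.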

Compound 4, half-maximal inhibitory concentration: 36 nM
Estimate against measurement, compound 4: 3.6-fold (0.56 log units) above, outside the stated range (below it).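

In this assay, the change from 4-fluorophenyl to 4-methoxyphenyl gives a 4.4-fold lower number from compound 2 to compound 4 (0.64 log units; beyond the scatter), and methoxy in place of fluoro does not carry over at one size between the two cores: the same change on two cores in this assay, a 1.3-fold lower number (0.12 log units; within the scatter) from compound 1 to compound 3 and a 4.4-fold lower number (0.64 log units; beyond the scatter) from compound 2 to compound 4, 3.3-fold (0.52 log units) apart, beyond the scatter of two such steps

On the core of compound 2 the change therefore gives a step beyond the scatter, whereas on the core of compound 1 the step of a 1.3-fold lower number from compound 1 to compound 3 (0.12 log units; within the scatter) stays within it, so the earlier pair alone was a poor guide to the size of the step on the second core. The gap cannot be assigned to the core or to the place of the methoxy, as the two pairs differ in both, and with a single pair on each core the data show neither a general rule for this change nor which part of the core matters.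

Open, from the compounds shown here alone, is whether the two cores would still part if methoxy stood at the same place on the pendant ring in both. Also open, going by these compounds, is how an amine or a longer chain such as ethoxy, para to a large group on the core of compound 2, would compare with the methoxy of compound 4.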